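Notes on the thiophen-2-yl step to compound 4

This account rests on a few compounds, and the source may have more. Where it says the series, first, only, none or still open, it means among the compounds named here.

- compound 1 `CCCCCCCCc1ccc(OCC(=O)Cn2nnnc2C)cc1` gives 32%
- compound 2 `CCCCCCCCc1ccc(OCC(=O)Cn2nnnc2-c2cccc(Cl)c2)cc1` gives 41%
- compound 3 `CCCCCCCCc1ccc(OCC(=O)Cn2nnnc2-c2ccc(S(=O)(=O)N(C)C)cc2)cc1` gives 40%

These numbers come from an ADME assay on S9 fraction from liver (Rattus norvegicus) for metabolic stability, read by LC-MS, using NADPH, with a stated time of 30 min (a higher number here means that more of the compound is left, a lower number that less of the compound is left), and all three lie within the scatter of one another, so compound 3 at 40% holds no separate place in the set. The next structure is compound 4 `CCCCCCCCc1ccc(OCC(=O)Cn2nnnc2-c2cccs2)cc1` with thiophen-2-yl in place of 4-(dimethylsulfamoyl)phenyl on an aromatic carbon, between two ring nitrogen atoms. The change is thiophen-2-yl in place of 4-(dimethylsulfamoyl)phenyl on an aromatic carbon and it falls at the one place varied so far. Three measured steps at that place bear on it, namely a number 9 percentage points higher from compound 1 to compound 2 (within the scatter) and a number 8 percentage points higher from compound 1 to compound 3 (within the scatter) and a number 1 percentage points lower from compound 2 to compound 3 (within the scatter) as the closest parallel, since it exchanges one ring-bearing group for another. None of them leaves the scatter, so no step beyond the scatter is expected in this assay and no direction is favoured. The expected step is a number 2 percentage points lower from compound 3 to compound 4 (within the scatter) and no more than that is read into it. Compound 4 is estimated at 38% with an expected range from 26% to 50% for a single measurement.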

Compound 4, percent of the compound remaining: 27%
Estimate against measurement, compound 4: 11 percentage points above, and the stated range covers the measured number.
By their numbers in this assay, from the lowest: compounds 4, 1, 3 and 2 (each within the scatter of the next, the first and the last beyond it).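

In this assay, within the data shown here, the group on the aromatic carbon of the five-membered aromatic ring with 4 nitrogen now gives modest steps beyond the scatter, which no earlier pair at this position did (a number 13 percentage points lower from compound 3 to compound 4 (beyond the scatter); a number 14 percentage points lower from compound 2 to compound 4 (beyond the scatter)). Thiophen-2-yl therefore separates from both 4-(dimethylsulfamoyl)phenyl and 3-chlorophenyl, but not from methyl (a number 5 percentage points lower from compound 1 to compound 4 (within the scatter)). Nothing given here accounts for this difference.

Still open, as far as these compounds go, is whether an unsubstituted phenyl or a furan-2-yl would read with thiophen-2-yl or with the two substituted phenyl groups. Also open, from the compounds shown here alone, is whether these steps would hold with a shorter chain in place of the octyl chain on the shared core.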